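A few compounds are considered here, and "the series" means these few. Any claim that something is new, unique, unknown or untested is made for them only; others in the source may bear on it.

Working notes on the series. In a functional assay on MCF7 cells (Homo sapiens) for cytotoxicity, read by MTT assay, with a stated time of 24 h (a lower number here means a stronger inhibitor, a higher number a weaker inhibitor), compound 1 `Cc1cc(O)c(C(=O)/C=C/c2ccccc2Cl)c(-c2ccc(Cl)cc2)c1C(=O)/C=C/c1ccccc1Cl` gives 30000 nM. In this assay compound 2 `Cc1cc(O)c(C(=O)/C=C/c2ccc(Cl)cc2)c(-c2ccc(Cl)cc2)c1C(=O)/C=C/c1ccc(Cl)cc1` gives 28000 nM. In this assay compound 3 `Cc1cc(O)c(C(=O)/C=C/c2cccc3ccccc23)c(-c2ccc(Cl)cc2)c1C(=O)/C=C/c1cccc2ccccc12` gives 30000 nM. Compound 2 holds the lowest of the three numbers, yet its gap to compound 1 and its gap to compound 3 both lie within the scatter, so the three values sit together and no order among them can be read. The aryl groups on the two enone arms vary across these three compounds without moving the number.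

Compound 4 `Cc1cc(O)c(C(=O)/C=C/c2ccc(Cl)cc2)c(-c2ccc(Br)cc2)c1C(=O)/C=C/c1ccc(Cl)cc1` has not yet been measured in this assay. Its difference from compound 2 is bromo in place of chloro on an aromatic carbon. Among the compounds with values here, no step between measured compounds covers this change, and the enone arms and the shared core remain untouched. The expected step of no change at the digits printed from compound 2 to compound 4 (within the scatter) in this assay is none beyond the scatter. This expectation rests on compound 2, which gives 28000 nM in this assay. For compound 4 the expected value in this assay is 28000 nM, with a range from 14000 nM to 56000 nM.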

Compound 4, half-maximal inhibitory concentration: 20000 nM
For compound 4 the middle estimate is 1.4-fold (0.15 log units) above the measured one; low and high end bracket the measured number.
By their numbers in this assay, from the lowest: compounds 4, 2, 1 and 3 (each within the scatter of the next).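

In this assay, 4-chlorophenyl to 4-bromophenyl gives a 1.4-fold lower number from compound 2 to compound 4 (0.15 log units; within the scatter), so this halogen exchange produces no readable change. Within the data shown here, compounds 1, 2 and 3 showed only that varying the aryl groups on the enone arms left the number unmoved, whereas this result is the first reading at the aromatic ring carried directly by the shared core, and that ring also shows no response to this exchange. No measured evidence bears on this result.

Two halogens on one aromatic carbon do not show whether this ring can move the number at all. Going by these compounds, an amine, a methoxy group or a carboxylic acid on that carbon remains open, as does the same carbon carrying only hydrogen.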